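Triazole ethers: halophenyl swap with every value at the limit

A few compounds are considered here, and "the series" means these few. Any claim that something is new, unique, unknown or untested is made for them only; others in the source may bear on it.

Compound 1 `Clc1cccc(Cn2cc(COc3ccccc3)nn2)c1` is the reference point of this small set. In an ADME assay on A549 cells (Homo sapiens) for inhibition, read by MTT assay, with a stated time of 48 h (on this read-out lower numbers stand for stronger inhibition of growth and higher numbers for weaker inhibition of growth), compound 1 gives only a limit, > 100 ug/mL. Compound 2 `Brc1ccc(Cn2cc(COc3ccccc3)nn2)cc1` differs from it by 4-bromophenyl in place of 3-chlorophenyl on a saturated chain carbon bound to an aromatic nitrogen. In this assay compound 2 likewise gives only a limit, > 100 ug/mL. The step that the two limits leave unreadable from compound 1 to compound 2 therefore has no readable size. Compound 3 `Clc1ccc(OCc2cn(Cc3cccc(Cl)c3)nn2)cc1` differs from compound 1 in the core, by chloro in place of hydrogen on an aromatic carbon. In this assay compound 3 also gives only a limit, > 100 ug/mL. The step that the two limits leave unreadable from compound 1 to compound 3 is equally unreadable. Every measured value sits at the limit of > 100 ug/mL in this assay, at which 3 of the 3 values shown sit, so nothing in the set has yet separated from anything else.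

Compound 4 `Clc1ccc(OCc2cn(Cc3ccc(Br)cc3)nn2)cc1` has not been measured. It is related to compound 3 by 4-bromophenyl in place of 3-chlorophenyl on a saturated chain carbon bound to an aromatic nitrogen, which is the same change as that from compound 1 to compound 2, made at a place described in identical words. In this assay compound 4 is expected to give about 150 ug/mL, with a plausible range from 60 ug/mL to 400 ug/mL. The expected step that the limit leaves unreadable from compound 3 to compound 4 is close to none, because the corresponding step that the two limits leave unreadable from compound 1 to compound 2 produced no change that could be read off, with both of its values at the limit of > 100 ug/mL in this assay, at which 3 of the 3 values shown sit. The most likely outcome for compound 4 is that only a limit is reported again, and any numerical reading below that limit would be a departure from the whole pattern seen so far.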

Compound 4, concentration for 50% growth inhibition: > 100 ug/mL
Compound 4 gave a limit, no number; the forecaster's own chance of this, stated with the estimate: 85%; the middle value does not contradict the limit.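

In this assay compound 4 gives only a limit, so the steps linking it to compound 3 and compound 2 cannot be read, and no new comparison follows: the limit of > 100 ug/mL in this assay, at which 4 of the 4 values shown sit.

The compounds shown leave open whether 4-bromophenyl in place of 3-chlorophenyl, or chloro in place of hydrogen on an aromatic carbon, alters growth inhibition at all, since compound 1, compound 2, compound 3 and compound 4 yield no numerical reading.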